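From 3,4-dichlorophenyl to 2-methoxyphenyl on a shared core

This account rests on a few compounds, and the source may have more. Where it says the series, first, only, none or still open, it means among the compounds named here.

In a functional assay on Jurkat cells (Homo sapiens) for antiproliferative activity, read by MTT assay, with a stated time of 72 h (a higher number here means a weaker inhibitor, a lower number a stronger inhibitor), compound 1 (`CCOc1ccc(-c2ncnn2-c2cc(OC)c(OC)c(OC)c2)cc1Cl`) gives 3 nM as its half-maximal inhibitory concentration. Compound 2 (`COc1cc(-n2ncnc2-c2ccc(Cl)c(Cl)c2)cc(OC)c1OC`) gives > 10000 nM as a limit and not a number. Compound 3 (`COc1cc(-c2ncnn2-c2ccccc2)cc(OC)c1OC`) gives > 10000 nM as a limit too. Compound 2 thus shares its place with compound 3 (the limit of > 10000 nM in this assay, at which 2 of the 3 values shown sit), and no true number is known for either.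

Compound 4 (`COc1ccccc1-c1ncnn1-c1cc(OC)c(OC)c(OC)c1`) has not yet been measured. It carries 2-methoxyphenyl in place of 3,4-dichlorophenyl on an aromatic carbon, and the rest of the structure stays as in compound 2.

Among the compounds with values here, the one measured step that bears on this change is an at least 3300-fold higher number from compound 1 to compound 2 (3.52 log units; beyond the scatter) and it is large, with chloro in place of ethoxy on an aromatic carbon. It shows that a single group can matter greatly in this assay. However, compound 1 reaches 3 nM with an ethoxy group that compound 4 does not carry, so no large fall in the number is expected. The estimated change is a number no higher from compound 2 to compound 4 (the limit leaves the size open) and no step beyond the scatter is expected. For compound 4 the estimate is 10000 nM with an expected range from 1000 nM to 30000 nM in this measurement.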

Compound 4, half-maximal inhibitory concentration: > 10000 nM
Compound 4 was reported as a limit (the forecaster's own chance of this, stated with the estimate: 70%); the middle value sits exactly at the limit.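

In this assay compound 4 gives > 10000 nM, a limit and not a number. Compound 2 stands at a limit as well, and the step between the two cannot be read: the limit of > 10000 nM in this assay, at which 3 of the 4 values shown sit.

The compounds shown leave open the true values of compound 2 and compound 4, and so whether 3,4-dichlorophenyl and 2-methoxyphenyl differ at all on the shared core.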